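Hydroxy for Fluoro on Two Diacetate Cores

This account rests on a few compounds, and the source may have more. Where it says the series, first, only, none or still open, it means among the compounds named here.

The series holds four compounds. Compound 1 `COc1nc(CC(O)(COC(C)=O)COC(C)=O)c(C)c(OC)n1` and compound 2 `COc1nc(CC(F)(COC(C)=O)COC(C)=O)c(C)c(OC)n1` share one core; compound 3 `COc1nc(=O)n(C)c(CC(F)(COC(C)=O)COC(C)=O)c1C` and compound 4 `COc1nc(=O)n(C)c(CC(O)(COC(C)=O)COC(C)=O)c1C` share another. The two cores have the same atoms joined differently, and how they differ is not broken down here.

In a functional assay on SW-620 cells (Homo sapiens) for antiproliferative activity, read by MTT assay, with a stated time of 72 h (on this read-out lower numbers stand for stronger inhibition and higher numbers for weaker inhibition), compound 1 gives only a limit, > 100000 nM. Compound 2 gives only a limit as well, > 100000 nM. Compound 3 likewise gives only a limit, > 100000 nM. For the measured compounds named here, the single measured instance of the change, (hydroxy in place of fluoro on a saturated chain carbon bound to three saturated chain carbons), therefore yields a step that the two limits leave unreadable from compound 2 to compound 1, and nothing about its size can be taken from it.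

From compound 3 to compound 4 the same change is made, (hydroxy in place of fluoro on a saturated chain carbon bound to three saturated chain carbons), and the place is described in the same words for both pairs. Going by the values given here, the expected step of a number no higher from compound 3 to compound 4 (the limit leaves the size open) is set at no movement because the limit of > 100000 nM in this assay, at which 3 of the 3 values shown sit, puts every compound that has a value at that limit, and the one instance of the change seen so far left no readable step. Compound 4 is therefore expected to return only a limit as well, with an estimate of 100000 nM. For compound 4 the estimated range from 30000 nM to 300000 nM leaves some room for a reading just inside the window, but a numeric value is not expected.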

Compound 4, half-maximal inhibitory concentration: > 100000 nM
Compound 4 ended at the assay's limit; the forecaster's own chance of this, stated with the estimate: 85%; the middle value lies on the limit itself.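

No new step can be read from compound 3 to compound 4, since both end at a limit and not at a number: the limit of > 100000 nM in this assay, at which 4 of the 4 values shown sit.

The compounds shown leave open whether hydroxy in place of fluoro on a saturated chain carbon bound to three saturated chain carbons moves the read-out at all, in either direction, on either core.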